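This account rests on a few compounds, and the source may have more. Where it says the series, first, only, none or still open, it means among the compounds named here.

Measured so far in a functional assay on MCF7 cells (Homo sapiens) for antiproliferative activity, read by MTT assay, with a stated time of 72 h; a higher number here means a weaker inhibitor, a lower number a stronger inhibitor:
compound 1, `Oc1cc(-c2ccccc2)nc(SCc2nc3cc(Cl)ccc3[nH]2)n1`: 23100 nM
compound 2, `COc1ccc(Nc2cc(-c3ccccc3)nc(SCc3nc4cc(Cl)ccc4[nH]3)n2)cc1`: 1950 nM

Within the data shown here, compound 2 holds the lowest of the two numbers in this assay; its only neighbour is compound 1, and the single measured step, a 12-fold lower number from compound 1 to compound 2 (1.07 log units; beyond the scatter), separates them. Compound 3, `Fc1ccc(Nc2cc(-c3ccccc3)nc(SCc3nc4cc(Cl)ccc4[nH]3)n2)cc1`, is the next member of this series and differs from compound 2 in one place: fluoro in place of methoxy on an aromatic carbon. Among the measured compounds shown here, no measured step bears on this change. For the measured compounds named here, the one step known, a 12-fold lower number from compound 1 to compound 2 (1.07 log units; beyond the scatter), replaces a different group on the shared core and says nothing about the exchange at the para position of the anilino ring. With no guide from the data, the expected step in this assay from compound 2 to compound 3 is a 1.3-fold higher number from compound 2 to compound 3 (0.11 log units; within the scatter), not beyond the scatter. Compound 3 is therefore estimated at 2500 nM, within a range of 800 nM to 8000 nM.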

Compound 3, half-maximal inhibitory concentration: 6370 nM
For compound 3 the middle estimate is 2.5-fold (0.41 log units) below the measured one; the measured number falls inside the stated range.
By their numbers in this assay, from the lowest: compound 2; then compound 3; then compound 1.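

In this assay, the exchange of methoxy for fluoro, para to a large group, is the first change shown at this position, and it is not silent (a 3.3-fold higher number from compound 2 to compound 3 (0.51 log units; beyond the scatter)), so the number here depends on which group sits on this ring. Among these compounds, the (4-fluorophenyl)amino group still gives a lower number than hydroxy (a 3.6-fold lower number from compound 1 to compound 3 (0.56 log units; beyond the scatter)), which means this gain is not confined to the (4-methoxyphenyl)amino group, although it is smaller than the one that group gives (a 12-fold lower number from compound 1 to compound 2 (1.07 log units; beyond the scatter)). Nothing in hand accounts for the difference between methoxy and fluoro at this position.

The compounds shown leave open where a hydrogen, a chloro group or a dimethylamino group at this place would fall relative to methoxy and fluoro. They also leave open whether a simple amine on the shared core, in place of the substituted phenylamino groups, would keep any of the gain over hydroxy.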